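The source may report more compounds than this note shows. Statements on the series, on what has been measured and on what is new or still open speak of the compounds shown alone.

In an ADME assay on HEK-293T cells (Homo sapiens) for cytotoxicity, read by MTT assay, with a stated time of 72 h (a higher number here means a weaker inhibitor, a lower number a stronger inhibitor), compound 1 `O=C(Nc1nc2ccc(Cl)cc2s1)c1cn(-c2ccccc2)nc1-c1ccccc1` gives 21300 nM. Compound 2 `COc1ccc2nc(NC(=O)c3cn(-c4ccccc4)nc3-c3ccccc3)sc2c1` is the analogue with methoxy in place of chloro on an aromatic carbon, and in this assay compound 2 is recorded only as a limit, > 50000 nM. That limit is the assay's own ceiling, (the limit of > 50000 nM in this assay, at which 1 of the 3 values shown sits), so the change from compound 1 to compound 2 appears as an at least 2.3-fold higher number from compound 1 to compound 2 (0.37 log units; beyond the scatter), an increase whose full size is not known. Compound 3 `COc1ccc(-c2nn(-c3ccccc3)cc2C(=O)Nc2nc3ccc(Cl)cc3s2)cc1` differs from compound 1 by methoxy in place of hydrogen on an aromatic carbon; in this assay compound 3 gives 12600 nM, and the step from compound 1 to compound 3 is a 1.7-fold lower number from compound 1 to compound 3 (0.23 log units; within the scatter), too small to count as a change.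

Compound 4 `COc1ccc(-c2nn(-c3ccccc3)cc2C(=O)Nc2nc3ccc(OC)cc3s2)cc1` has not yet been measured. It stands to compound 3 as compound 2 stands to compound 1: the difference is methoxy in place of chloro on an aromatic carbon, the same change at the same place on the fused ring system, the two cores differing only in the methoxy of compound 3 described above. Among the compounds with values here, since the one earlier instance of this change, from compound 1 to compound 2, reached the limit, compound 4 is expected to move upward by a 3.0-fold higher number from compound 3 to compound 4 (0.48 log units; beyond the scatter), with a real chance that the assay again reports only a limit. The estimate for compound 4 in this assay is 38000 nM, expected to lie between 14000 nM and 90000 nM.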

Compound 4, half-maximal inhibitory concentration: > 50000 nM
Compound 4: no number, only a limit (the forecaster's own chance of this, stated with the estimate: 50%); at least 1.3-fold (0.11 log units) between middle value and limit.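

In this assay compound 4 is recorded only as a limit, > 50000 nM. On the second core, the change from 6-chloro-1,3-benzothiazol-2-yl to 6-methoxy-1,3-benzothiazol-2-yl gives an at least 3.9-fold higher number from compound 3 to compound 4 (0.59 log units; beyond the scatter), so the number rises beyond the scatter on both cores and the direction of the change carries over from the core of compound 1 to the core of compound 3: the same change on two cores in this assay, an at least 2.3-fold higher number (0.37 log units; beyond the scatter) from compound 1 to compound 2 and an at least 3.9-fold higher number (0.59 log units; beyond the scatter) from compound 3 to compound 4; the limit leaves it open whether they differ Both steps end at the ceiling of the assay, so the full size of neither is known and the data do not show whether the change is larger on one core than on the other: the limit of > 50000 nM in this assay, at which 2 of the 4 values shown sit.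

The step between compound 2 and compound 4 cannot be read, which leaves open what methoxy in place of hydrogen does when the 6-methoxy group is present. As far as these compounds go, it also remains open how an amine, a carboxylic acid or a longer chain in place of chloro would read in this assay.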